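The source may hold more compounds than are shown below. What is called first, only, known or untested is meant among the compounds shown, and "the series" means these compounds.

Compound 1, `Cc1cn([C@H]2C[C@H](CN)[C@@H](COP(=O)(O)O)O2)c(=O)[nH]c1=O`: in an assay on isolated protein for inhibition of thymidine kinase, cytosolic (Homo sapiens) (a higher number here means a weaker inhibitor, a lower number a stronger inhibitor), compound 1 gives 4700 nM.
Compound 2, `Cc1cn([C@H]2C[C@H](CN)[C@@H](CO)O2)c(=O)[nH]c1=O`: in this assay compound 2 gives 220000 nM.
Compound 3, `Cc1cn([C@H]2C[C@H](CO)[C@@H](CO)O2)c(=O)[nH]c1=O`: in this assay compound 3 gives 420000 nM.

The change from compound 2 to compound 1 is a group of 4 heavy atoms (3 oxygen, 1 phosphorus; no ring) in place of a hydrogen atom, on an oxygen on a saturated carbon, and it made a step of a 47-fold lower number from compound 2 to compound 1 (1.67 log units; beyond the scatter). The two cores differ by hydroxy in place of amino on a saturated chain carbon bound to a saturated ring carbon, a step of a 1.9-fold higher number from compound 2 to compound 3 (0.28 log units; within the scatter), so compound 2 and compound 3 sit close together. Compound 4, `Cc1cn([C@H]2C[C@H](CO)[C@@H](COP(=O)(O)O)O2)c(=O)[nH]c1=O`, carries the same change on the core of compound 3: a group of 4 heavy atoms (3 oxygen, 1 phosphorus; no ring) in place of a hydrogen atom, on an oxygen on a saturated carbon, at a place described in the same words as before. The same change is therefore expected to give about the same step. For compound 4 the expected step is a 42-fold lower number from compound 3 to compound 4 (1.62 log units; beyond the scatter), resting on the earlier step of a 47-fold lower number from compound 2 to compound 1 (1.67 log units; beyond the scatter). Compound 4 is estimated at 10000 nM, likely between 3000 nM and 40000 nM.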

Compound 4, inhibition constant: 43500 nM
Compound 4: the middle estimate sits 4.4-fold (0.64 log units) below what was measured, outside the stated range (above it).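

On the core carrying hydroxy, the phosphorus-bearing group still lowers the number, a step of a 9.7-fold lower number from compound 3 to compound 4 (0.98 log units; beyond the scatter), but the size of this step does not carry over from the core carrying amino: the same change on two cores in this assay, a 47-fold lower number (1.67 log units; beyond the scatter) from compound 2 to compound 1 and a 9.7-fold lower number (0.98 log units; beyond the scatter) from compound 3 to compound 4, 4.8-fold (0.69 log units) apart, beyond the scatter of two such steps. Seen the other way, swapping amino for hydroxy matters far more once the phosphorus-bearing group is present, a step of a 9.3-fold higher number from compound 1 to compound 4 (0.97 log units; beyond the scatter), so the two changes do not simply add up: the same change on two cores in this assay, a 1.9-fold higher number (0.28 log units; within the scatter) from compound 2 to compound 3 and a 9.3-fold higher number (0.97 log units; beyond the scatter) from compound 1 to compound 4, 4.8-fold (0.69 log units) apart, beyond the scatter of two such steps. Two cores show that the step size depends on the core, but they cannot show why, or what size to expect on a third core. The compounds shown leave open how a longer chain ending in an amine, or a carboxylic acid, would behave in place of the amino or hydroxy group. They also leave open whether a smaller group, such as a methyl ether, would give any of the same step as the phosphorus-bearing group.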